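The source may hold more compounds than are shown below. What is called first, only, known or untested is meant among the compounds shown, and "the series" means these compounds.

Measured compounds and their values:
- compound 1 `O=c1nc2oc(C3CC3)c(C#CC3CC3)c2cn1Cc1cn(Cc2ccccc2)nn1`: 9720 nM
- compound 2 `O=c1nc2oc(CCCCl)cc2cn1Cc1cn(Cc2ccccc2)nn1`: 75500 nM
- compound 3 `O=c1nc2oc(CCCCl)cc2cn1Cc1cn(-c2ccc(Cl)cc2)nn1`: a limit, > 100000 nM

In a functional assay on SW-620 cells (Homo sapiens) for antiproliferative activity, read by MTT assay, with a stated time of 72 h (a lower number here means a stronger inhibitor, a higher number a weaker inhibitor), compound 1 gives 9720 nM, the lowest of the two numbers reported. Compound 2 gives 75500 nM in this assay. For compound 3 this assay reports only a limit, > 100000 nM, which is the limit of > 100000 nM in this assay, at which 1 of the 3 values shown sits, and not a number. Compound 1 and compound 2 have different cores, and that difference is not broken down here.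

Compound 3 differs from compound 2 by 4-chlorophenyl in place of benzyl on an aromatic nitrogen. As far as these compounds go, this change gave an at least 1.3-fold higher number from compound 2 to compound 3 (0.12 log units; that floor lies within the scatter), and because compound 3 sits at the limit of > 100000 nM in this assay, at which 1 of the 3 values shown sits, the full size of that step stays unknown.

Compound 4 `O=c1nc2oc(C3CC3)c(C#CC3CC3)c2cn1Cc1cn(-c2ccc(Cl)cc2)nn1` is not yet measured. It differs from compound 1 by 4-chlorophenyl in place of benzyl on an aromatic nitrogen, the same change at the same place. Resting on the step of an at least 1.3-fold higher number from compound 2 to compound 3 (0.12 log units; that floor lies within the scatter), compound 4 is expected to be a weaker inhibitor than compound 1, with a step of roughly a 3.6-fold higher number from compound 1 to compound 4 (0.56 log units; beyond the scatter) expected. Compound 4 is estimated at about 35000 nM, with a likely range from 12000 nM to 100000 nM.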

Compound 4, half-maximal inhibitory concentration: 36900 nM
For compound 4 the middle estimate is 1.1-fold (0.02 log units) below the measured one, within the range that was stated.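

In this assay, 4-chlorophenyl in place of benzyl gives a 3.8-fold higher number from compound 1 to compound 4 (0.58 log units; beyond the scatter), so on this core the change clearly weakens the inhibitor. As far as these compounds go, two cores are too few to call this a rule, and whether the step has the same size on both remains open: the same change on two cores in this assay, an at least 1.3-fold higher number (0.12 log units; that floor lies within the scatter) from compound 2 to compound 3 and a 3.8-fold higher number (0.58 log units; beyond the scatter) from compound 1 to compound 4; the limit leaves it open whether they differ. For compound 3 the assay gives > 100000 nM, which is a limit and not a number.

The compounds shown leave open which part of the change counts, the chlorine or the loss of the carbon link between the phenyl ring and the aromatic nitrogen, a question that plain phenyl or 4-chlorobenzyl at that place could help to answer. From the compounds shown here alone, how a longer chain such as phenethyl, or a phenyl ring carrying an amine or a carboxylic acid, would behave on that nitrogen is also open.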